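Azetidinylmethoxypyridines: nitro to phenyl on the pyridine ring

The source may hold more compounds than are shown below. What is called first, only, known or untested is meant among the compounds shown, and "the series" means these compounds.

Two compounds of the series have numbers. In an assay on brain for binding affinity to Neuronal acetylcholine receptor; alpha4/beta2 (Rattus norvegicus), read by radioligand binding (on this read-out lower numbers stand for stronger inhibition and higher numbers for weaker inhibition), compound 1 `Nc1cncc(OC[C@@H]2CCN2)c1` gives 0.082 nM, and compound 2 `O=[N+]([O-])c1cncc(OC[C@@H]2CCN2)c1` gives 0.33 nM. Among the compounds with values here, the one step between them, a 4.0-fold higher number from compound 1 to compound 2 (0.60 log units; beyond the scatter), stands as the only measured change so far. Compound 2 therefore holds the higher of the two numbers, with compound 1 the lower.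

Compound 3 `c1ccc(-c2cncc(OC[C@@H]3CCN3)c2)cc1` differs from compound 2 by phenyl in place of nitro on an aromatic carbon. Within the data shown here, no measured step exchanges a nitro for a phenyl, so the only bearing comes from the amino-to-nitro step, which moved the number by a modest amount. A change of at least similar size is expected here, in the direction of higher numbers in this assay, though the direction is not secured by any measured pair.

Compound 3 is expected to show a 6.1-fold higher number from compound 2 to compound 3 (0.78 log units; beyond the scatter). For compound 3 the estimate in this assay is 2 nM, within a range of 0.3 nM to 15 nM.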

Compound 3, inhibition constant: 0.046 nM
Compound 3: the middle estimate sits 43-fold (1.64 log units) above what was measured; measured number outside the range, below it.
By their numbers in this assay, from the lowest: compounds 3 and 1 (each within the scatter of the next); then compound 2.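

Phenyl in place of nitro on this aromatic carbon, two atoms from the ring nitrogen, gives a 7.2-fold lower number from compound 2 to compound 3 (0.86 log units; beyond the scatter) in this assay and thus shows that this position accepts a six-membered aromatic ring of carbon only while the number falls. Phenyl in place of amino gives a 1.8-fold lower number from compound 1 to compound 3 (0.25 log units; within the scatter) and stays within the scatter, so compound 3 and compound 1 cannot be ordered, and a group with 0 hydrogen-bond donors and 0 hydrogen-bond acceptors reaches the level of compound 1 here. No data on hand explain either step.

As far as these compounds go, whether the level of compound 3 holds with a methoxy or a chlorine on the phenyl remains open. So does the result of a methyl or a benzyl at this position, which would show whether an aromatic ring is needed.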